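The source may hold more compounds than are shown below. What is called first, only, known or untested is meant among the compounds shown, and "the series" means these compounds.

In a functional assay on SGC-7901 cells (Homo sapiens) for antiproliferative activity, read by MTT assay, with a stated time of 24 h (on this read-out higher numbers stand for weaker inhibition and lower numbers for stronger inhibition), compound 1 (`O=C(NNc1ccccc1F)c1ccccc1NS(=O)(=O)c1cnc(O)nc1O`) gives > 20000 nM, which is a limit and not a number. Compound 2 (`Cc1ccccc1C(=O)NNC(=O)c1ccc(NS(=O)(=O)c2cnc(O)nc2O)cc1`) gives > 20000 nM, also a limit. Compound 3 (`Cc1ccc(C(=O)NNC(=O)c2ccc(NS(=O)(=O)c3cnc(O)nc3O)cc2)cc1`) gives > 20000 nM, again a limit. The evidence so far is thus (the limit of > 20000 nM in this assay, at which 3 of the 3 values shown sit). Compound 4 (`O=C(NNC(=O)c1ccccc1NS(=O)(=O)c1cnc(O)nc1O)c1cccc(Cl)c1`) departs from compound 1 through ((3-chlorophenyl)carbonyl in place of 2-fluorophenyl on an amine nitrogen), so that (3-chlorophenyl)carbonyl stands in place of 2-fluorophenyl on an amine nitrogen. Within the data shown here, the only measured step, a step that the two limits leave unreadable from compound 2 to compound 3, involves a different change and offers no size to carry over. No clear gain in inhibition is therefore expected in this assay, and the expected change is a step that the limit leaves unreadable from compound 1 to compound 4. For compound 4 the estimate is 25000 nM, with an expected range of 12000 nM to 50000 nM.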

Compound 4, half-maximal inhibitory concentration: 1820 nM
The estimate for compound 4 lay 14-fold (1.14 log units) above the measured number, outside the stated range (below it).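

On the amine nitrogen of compound 1, (3-chlorophenyl)carbonyl in place of 2-fluorophenyl gives an at least 10-fold lower number from compound 1 to compound 4 (1.04 log units; beyond the scatter) in this assay. Among these compounds, this position can therefore move the read-out by a large step, which the earlier compounds could not show. Compound 4 alone gives a number, while the others remain at a limit: the limit of > 20000 nM in this assay, at which 3 of the 4 values shown sit.

The change brings in the carbonyl and the chlorine together, and the compounds shown do not separate them. A plain phenylcarbonyl group or a 3-chlorophenyl group on that nitrogen would leave open which part the step follows.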